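A few compounds are considered here, and "the series" means these few. Any claim that something is new, unique, unknown or untested is made for them only; others in the source may bear on it.

Measured in a functional assay on HGC-27 cells (Homo sapiens) for antiproliferative activity, read by MTT assay, with stated times of 72 h and 4 h; on this read-out higher numbers stand for weaker inhibition and lower numbers for stronger inhibition:

Compound 1 `COc1ncc(-c2cc3c(N4C[C@@H](C)O[C@@H](C)C4)ncnc3s2)cc1NS(=O)(=O)c1ccc(F)cc1F`: 560 nM
Compound 2 `COc1ncc(-c2cc3c(N4CCC(OC)CC4)ncnc3s2)cc1NS(=O)(=O)c1ccc(F)cc1F`: 280 nM
Compound 3 `COc1ncc(-c2nc3c(N4CCC(OC)CC4)ncnc3s2)cc1NS(=O)(=O)c1ccc(F)cc1F`: 74 nM

Compound 3 has the lowest of these three numbers, and its gaps to compound 1 and compound 2 both lie beyond the scatter. Its core differs from the core shared by compound 1 and compound 2.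

Compound 4 `COc1ncc(-c2nc3c(N4CCCC4)ncnc3s2)cc1NS(=O)(=O)c1ccc(F)cc1F` keeps the core of compound 3 but has pyrrolidin-1-yl in place of 4-methoxypiperidin-1-yl on an aromatic carbon.

Among the measured compounds shown here, only one measured step exchanges one ring group for another, and it does so on the other core. That step, a 2.0-fold lower number from compound 1 to compound 2 (0.30 log units; within the scatter), stays within the scatter, so it gives a modest reason to expect only a small effect here. For the measured compounds named here, no measured compound carries pyrrolidin-1-yl, so the direction is uncertain and the range must stay wide.

In this assay the expected result is a 1.5-fold higher number from compound 3 to compound 4 (0.17 log units; within the scatter), a small step to a higher number. Compound 4 is estimated at 110 nM, with an expected range of 35 nM to 350 nM.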

Compound 4, half-maximal inhibitory concentration: 1200 nM
Estimate against measurement, compound 4: 11-fold (1.04 log units) below; the whole stated range lies below it.
By their numbers in this assay, from the lowest: compound 3; then compounds 2 and 1 (each within the scatter of the next); then compound 4.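

This position on the core of compound 3, on an aromatic carbon next to the ring nitrogen, proves highly sensitive to the group it carries: in this assay, pyrrolidin-1-yl in place of 4-methoxypiperidin-1-yl gives a 16-fold higher number from compound 3 to compound 4 (1.21 log units; beyond the scatter). Among the compounds shown here, the only earlier exchange of one ring group for another, a 2.0-fold lower number from compound 1 to compound 2 (0.30 log units; within the scatter), stayed within the scatter, but it involved different groups on another core, so a small step there does not carry over to every ring exchange at this position. This change shortens the ring from six to five members and removes the methoxy group at once, and no measurement here explains the loss.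

The compounds shown leave open which of these two differences matters more. Plain piperidin-1-yl, or pyrrolidin-1-yl bearing a methoxy group, on the core of compound 3 would separate them.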